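Propyl for 2-fluorophenyl on the amide of compound 1

A few compounds are considered here, and "the series" means these few. Any claim that something is new, unique, unknown or untested is made for them only; others in the source may bear on it.

The measured compounds and their values:
Compound 1 `COc1ccc(-c2cnc(NC(=O)c3ccccc3F)n2C)cc1`: in a toxicity assay on THP-1 cells (Homo sapiens) for inhibition (a higher number here means that more compound is tolerated, a lower number that less compound is tolerated), compound 1 gives > 100000 nM, which is a limit of the assay and not a number.
Compound 2 `COc1ccc(CNC(=O)NC(=O)c2ccc(F)cc2)cc1`: in this assay compound 2 gives > 50000 nM, again a limit.
Compound 3 `COc1ccc(-c2cnc(NC(=O)c3ccc([N+](=O)[O-])cc3)n2C)cc1`: in this assay compound 3 gives > 100000 nM, again a limit.

Compound 1 therefore stands at the upper limit, together with compound 3, as the line the limit of > 100000 nM in this assay, at which 2 of the 3 values shown sit, records; compound 2 sits at the other limit, (the limit of > 50000 nM in this assay, at which 1 of the 3 values shown sits). For the measured compounds named here, no value here is a number, so no step between measured compounds can be sized, and nothing in these three results separates one from another.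

Compound 4 `CCCC(=O)Nc1ncc(-c2ccc(OC)cc2)n1C` differs from compound 1 in a single place: propyl in place of 2-fluorophenyl on a carbonyl carbon. Since every measured compound, whatever its amide substituent, reaches a limit in this assay, the step from compound 1 to compound 4 is expected to be none beyond the scatter, written as a number no higher from compound 1 to compound 4 (the limit leaves the size open). For compound 4 the estimate in this assay is 100000 nM, within 50000 nM to 200000 nM, most likely reported once more as a limit.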

Compound 4, half-maximal cytotoxic concentration: > 100000 nM
Compound 4: a limit, no number (the forecaster's own chance of this, stated with the estimate: 85%); the middle value sits exactly at the limit.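

For the compounds shown here, compound 1 and compound 4 both end at a limit of the assay rather than at a number, and no step between them can be read. The compounds shown leave open whether any amide substituent changes the tolerated concentration in this assay at all.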